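Alkoxy variation in the hydroxychalcone series: compound 4

The source may report more compounds than this note shows. Statements on the series, on what has been measured and on what is new or still open speak of the compounds shown alone.

Measured so far in a functional assay on NCI-H23 cells (Homo sapiens) for antiproliferative activity, read by sulforhodamine B assay; a lower number here means a stronger inhibitor of growth, a higher number a weaker inhibitor of growth:
Compound 1 `CC(C)=CCOc1cccc(O)c1C(=O)/C=C/c1ccc(O)cc1` gives > 30000 nM, a limit of the assay.
Compound 2 `O=C(/C=C/c1ccc(O)cc1)c1c(O)cccc1OCC1CCCC1` gives 3160 nM.
Compound 3 `CC(C)(C)CCOc1cccc(O)c1C(=O)CCc1ccc(O)cc1` gives > 30000 nM, a limit of the assay.

Among the measured compounds shown here, compound 2 holds the only number in this assay; the two other values sit at the limit of > 30000 nM in this assay, at which 2 of the 3 values shown sit. For the measured compounds named here, only one measured step changes a single place, an at least 9.4-fold lower number from compound 1 to compound 2 (0.97 log units; beyond the scatter), and it runs from an open chain toward the ring. Compound 4 `CC(C)COc1cccc(O)c1C(=O)/C=C/c1ccc(O)cc1` differs from compound 2 in the same place: isopropyl in place of cyclopentyl on a saturated chain carbon bound to an oxygen on an aromatic ring. This change runs the other way, from the ring back to a smaller open group, so on the basis of an at least 9.4-fold lower number from compound 1 to compound 2 (0.97 log units; beyond the scatter) a weaker inhibitor of growth than compound 2 is expected, though how far it falls is uncertain with a single step to go on. Compound 3, with a different chain, adds no number. Compound 4 is expected at 15000 nM, with a range from 4000 nM to 30000 nM. The expected step is a 4.7-fold higher number from compound 2 to compound 4 (0.68 log units; beyond the scatter), and there is a real chance the assay reports only a limit.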

Compound 4, concentration for 50% growth inhibition: 3220 nM
Beside the measured number, compound 4's estimate is 4.7-fold (0.67 log units) above it, and the stated range ends above it.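

In this assay, the ring of the cyclopentyl group proves dispensable at this place, on a saturated chain carbon bound to an oxygen on an aromatic ring: the open isopropyl group leaves the potency unchanged, with a 1.0-fold higher number from compound 2 to compound 4 (0.01 log units; within the scatter). The gain over compound 1 therefore does not need a ring, as an open group also gives an at least 9.3-fold lower number from compound 1 to compound 4 (0.96 log units; beyond the scatter), so the contrast is between the 2-methylprop-1-en-1-yl group and the two groups that hold numbers, not between ring and open chain. The value of compound 1 remains a limit of the assay, not a number: the limit of > 30000 nM in this assay, at which 2 of the 4 values shown sit.

The compounds shown do not tell how far this place tolerates other groups, such as a longer chain, a methyl group or a chain ending in an amine. Compound 3 differs from compound 4 in more than one place, so its limit says nothing about this change alone.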